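The compounds below may be only part of what the source reports. "The series", "measured", "known", "first", "only" and "open" are said of these compounds alone.

Three measured compounds share one core and differ only in the group attached to the thiocarbonyl carbon and in whether a chloro sits on an aromatic carbon. Compound 1 `O=c1cc(CSC(=S)N2CCCCC2)oc2cc(Cl)ccc12` carries piperidin-1-yl together with chloro, and in a functional assay on LM7 cells (Homo sapiens) for antiproliferative activity, read by MTT assay, with a stated time of 72 h (a lower number here means a stronger inhibitor, a higher number a weaker inhibitor), compound 1 gives 13800 nM. Compound 2 `O=c1cc(CSC(=S)N2CCCC2)oc2ccccc12` carries pyrrolidin-1-yl without chloro, and in this assay compound 2 gives 40000 nM. Compound 3 `O=c1cc(CSC(=S)N2CCCC2)oc2cc(Cl)ccc12` combines pyrrolidin-1-yl with chloro. For compound 3 this assay reports only a limit, > 25000 nM, not a number. Because of that limit (the limit of > 25000 nM in this assay, at which 1 of the 3 values shown sits), the step that the limit leaves unreadable from compound 2 to compound 3 cannot be read, while the step of an at least 1.8-fold higher number from compound 1 to compound 3 (0.25 log units; that floor lies within the scatter) has a floor that still lies within the scatter. Compound 3 therefore stands at or beyond the weak end of what has been measured, with no firm number.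

Compound 4 `CC(C)N(C(=S)SCc1cc(=O)c2ccc(Cl)cc2o1)C(C)C` differs from compound 3 in one place: diisopropylamino in place of pyrrolidin-1-yl on a thiocarbonyl carbon. Among the measured compounds shown here, no measured step swaps a ring on the thiocarbonyl carbon for an open chain; the nearest comparison, an at least 1.8-fold higher number from compound 1 to compound 3 (0.25 log units; that floor lies within the scatter), shows that changing the nitrogen group there moved the number little if at all. The expected step that the limit leaves unreadable from compound 3 to compound 4 is accordingly small, and compound 4 may again return only a limit. The estimate for compound 4 is 30000 nM, expected to fall between 10000 nM and 100000 nM.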

Compound 4, half-maximal inhibitory concentration: > 30000 nM
Compound 4: a limit, no number; the forecaster's own chance of this, stated with the estimate: 50%; the middle value sits exactly at the limit.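

Compound 4 returns no number in this assay, only a limit: the limit of > 30000 nM in this assay, at which 1 of the 4 values shown sits.

Among the compounds shown here, this gives the first change at the thiocarbonyl carbon that clearly clears the usual scatter: an at least 2.1-fold higher number from compound 1 to compound 4 (0.33 log units; beyond the scatter). For the compounds shown here, the earlier swap of piperidin-1-yl for pyrrolidin-1-yl could not show this, and among the three chloro compounds, compound 1 with its piperidin-1-yl is now the only one that gives a number rather than a limit. The step between compound 3 and compound 4 cannot be read, so the open-chain diisopropylamino group cannot be ranked against the pyrrolidin-1-yl ring.

As far as these compounds go, how far compound 3 and compound 4 lie beyond their limits remains open, and with it whether ring size or the change from ring to open chain matters more at this carbon. Also open, from the compounds shown here alone, is whether a smaller open amine such as dimethylamino, or a ring with an added oxygen such as morpholin-4-yl, would give a measurable number on the same core.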